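The compounds below may be only part of what the source reports. "The series", "measured", "known", "first", "only" and "open" are said of these compounds alone.

Working notes on the series, read in a functional assay on HT cells (Homo sapiens) for antiproliferative activity, read by fluorescence, with a stated time of 72 h; on this read-out lower numbers stand for stronger inhibition of growth and higher numbers for weaker inhibition of growth. Compound 1 (`CC(C)c1n[nH]c2c(NCc3ccc(-c4ccccn4)cc3)nc(SCC(O)CN)nc12`) gives 55 nM, compound 2 (`CC(C)c1n[nH]c2c(NCc3ccc(-c4ccccn4)cc3)nc(SC(CO)C(C)C)nc12`) gives 980 nM and compound 3 (`CNCCSc1nc(NCc2ccc(-c3ccccn3)cc2)c2[nH]nc(C(C)C)c2n1`) gives 56 nM. Compound 3 stands with compound 1 at the low end: the gap is a 1.0-fold higher number from compound 1 to compound 3 (0.01 log units; within the scatter). Against the remaining member, the gap is an 18-fold lower number from compound 2 to compound 3 (1.24 log units; beyond the scatter). Compound 4 (`CC(C)c1n[nH]c2c(NCc3ccc(-c4ccccn4)cc3)nc(SCCn3ccnc3)nc12`) differs from compound 3 as follows: 1H-imidazol-1-yl in place of methylamino on a saturated chain carbon, two bonds along the chain from a sulfur. Going by the values given here, no measured step makes this exchange. The nearest guides are changes to the group on sulfur, which gave a 1.0-fold higher number from compound 1 to compound 3 (0.01 log units; within the scatter) but also an 18-fold higher number from compound 1 to compound 2 (1.25 log units; beyond the scatter). A moderate rise is therefore expected in this assay, a 2.7-fold higher number from compound 3 to compound 4 (0.43 log units; beyond the scatter), smaller than the large steps. For compound 4 the estimate is 150 nM, with an expected range of 50 nM to 500 nM.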

Compound 4, concentration for 50% growth inhibition: 155 nM
Estimate against measurement, compound 4: 1.0-fold (0.01 log units) below; low and high end bracket the measured number.
By their numbers in this assay, from the lowest: compounds 1 and 3 (each within the scatter of the next); then compound 4; then compound 2.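

In this assay, 1H-imidazol-1-yl in place of methylamino at this place, two bonds along the chain from the sulfur, costs only a modest step (a 2.8-fold higher number from compound 3 to compound 4 (0.44 log units; beyond the scatter)), and the step against the 3-amino-2-hydroxypropyl chain is of the same order (a 2.8-fold higher number from compound 1 to compound 4 (0.45 log units; beyond the scatter)). The 2-(1H-imidazol-1-yl)ethyl group also remains well ahead of the branched 1-(hydroxymethyl)-2-methylpropyl group (a 6.3-fold lower number from compound 2 to compound 4 (0.80 log units; beyond the scatter)). Nothing available accounts for these differences.

Still open, going by these compounds, is whether a saturated ring such as piperidine at this place would behave like methylamino or like 1H-imidazol-1-yl. A longer chain between the sulfur and the imidazole ring also remains untested in the compounds shown.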